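Alkyne side group and half-life: from compound 2 to compound 3

The source may report more compounds than this note shows. Statements on the series, on what has been measured and on what is new or still open speak of the compounds shown alone.

Measured so far:
Compound 1 `NC(=O)c1cc(Cl)c2c(Cl)c(C#CC3CCOCC3)n([C@H]3CCCNC3)c2n1`: 10.2 h
Compound 2 `COCCC#Cc1c(Cl)c2c(Cl)cc(C(N)=O)nc2n1[C@H]1CCCNC1`: 3.59 h

In an ADME assay on the whole organism (Rattus norvegicus) for metabolic stability, at a dose of 10 mg/kg by the oral route (a lower number here means that the compound disappears faster, a higher number that the compound lasts longer), compound 1 gives 10.2 h and compound 2 gives 3.59 h. Within the data shown here, the single measured step, a 2.8-fold lower number from compound 1 to compound 2 (0.45 log units; beyond the scatter), leaves compound 2 with the lower of the two numbers, compound 1 being its only neighbour. Compound 3 `NC(=O)c1cc(Cl)c2c(Cl)c(C#CC3CCCO3)n([C@H]3CCCNC3)c2n1` is not yet measured; it differs from compound 2 by oxolan-2-yl in place of 2-methoxyethyl on a triple-bonded carbon. Among the measured compounds shown here, only the step from compound 1 to compound 2 bears on this change: there oxan-4-yl gave way to 2-methoxyethyl on the triple-bonded carbon and the half-life fell by a modest amount. Compound 3 carries a cyclic ether again, though a five-membered one, so a partial return towards the number of compound 1 is expected because of a 2.8-fold lower number from compound 1 to compound 2 (0.45 log units; beyond the scatter). Compound 3 is therefore estimated at 6.5 h (range 3.5 h to 12 h), an expected step of a 1.8-fold higher number from compound 2 to compound 3 (0.26 log units; within the scatter).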

Compound 3, half-life: 3.63 h
Compound 3: middle estimate off by 1.8-fold (0.25 log units), on the high side, and the stated range covers the measured number.
By their numbers in this assay, from the lowest: compounds 2 and 3 (each within the scatter of the next); then compound 1.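

In this assay the step to oxolan-2-yl on the triple-bonded carbon gives a 1.0-fold higher number from compound 2 to compound 3 (0.00 log units; within the scatter), so a ring in the side group does not by itself separate this group from the open-chain 2-methoxyethyl. Oxan-4-yl stands apart from oxolan-2-yl at this position, with a 2.8-fold lower number from compound 1 to compound 3 (0.45 log units; beyond the scatter), which shows that a cyclic ether as such does not carry the half-life of compound 1. No evidence is available on what lies behind these numbers.

Still open, on these data alone, is whether the longer half-life of compound 1 follows the ring of oxan-4-yl or the oxygen within it, a question that a cyclohexyl group at the same place would address. As far as these compounds go, how an amine or a carboxylic acid on the triple-bonded carbon would behave also remains open.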